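The compounds below may be only part of what the source reports. "The series", "measured", "known", "first", "only" and "open" are said of these compounds alone.

Measured compounds:
compound 1 `Cn1c(=O)c2nc(-c3cccc(F)c3)[nH]c2n(C)c1=O`, in an assay for binding affinity to adenosine receptor A1 (Bos taurus) (on this read-out lower numbers stand for stronger inhibition and higher numbers for weaker inhibition), compound 1 gives 4 nM
compound 2 `CCCn1c(=O)c2nc(-c3ccc(S(=O)(=O)NCCCC(=O)OCC)cc3)[nH]c2n(CCC)c1=O`, compound 2 gives 0.24 nM
compound 3 `Cn1c(=O)c2nc(-c3ccc(I)cc3)[nH]c2n(C)c1=O`, compound 3 gives 1.3 nM

Compound 3 holds the second highest of the three numbers; its nearest neighbour is compound 1 with a higher number, beyond the scatter, while compound 2 lies furthest off with a lower number, also beyond the scatter. Compound 4 `Cn1c(=O)c2nc(-c3ccc(F)cc3)[nH]c2n(C)c1=O` is not yet measured. It differs from compound 3 by fluoro in place of iodo on an aromatic carbon. Going by the values given here, no measured pair shows this exchange. Compound 1 also carries fluoro on the same ring, at another place, and gives a higher number than compound 3, so in this assay a modest upward step, probably beyond the scatter, is expected. Compound 4 is estimated at 5 nM, within 1.5 nM to 20 nM. The expected step is a 3.8-fold higher number from compound 3 to compound 4 (0.59 log units; beyond the scatter).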

Compound 4, half-maximal inhibitory concentration: 3.5 nM
Compound 4: the middle estimate sits 1.4-fold (0.15 log units) above what was measured, within the range that was stated.
By their numbers in this assay, from the lowest: compound 2; then compound 3; then compounds 4 and 1 (each within the scatter of the next).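

In this assay, fluoro in place of iodo on the aromatic carbon para to a large group gives a 2.7-fold higher number from compound 3 to compound 4 (0.43 log units; beyond the scatter) on the dimethyl-substituted core, a modest but readable sensitivity of this position to the halogen. Going by these compounds alone, this is the first single-place comparison. With fluoro at another place on the same ring, compound 1 gives 4 nM, within the scatter of compound 4, so moving fluoro shows no readable change.

Going by these compounds, whether chloro, bromo, an amine or a carboxylic acid at this position would fall in line with the two halogens remains open. Nothing at hand explains the step.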